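This account rests on a few compounds, and the source may have more. Where it says the series, first, only, none or still open, it means among the compounds named here.

Measured compounds and their values:
compound 1, `CC(C)=CCn1c(CN2CCN(C(=O)C3CC3)CC2)nc2ccccc21`, 74.3%;
compound 2, `CC(C)CCn1c(OC2CCN(C(=O)c3ccco3)CC2)nc2ccccc21`, 30.8%;
compound 3, `Cc1cccc(Cn2c(CN3CCN(C(=O)c4cccs4)CC3)nc3ccccc32)c1`, 60.8%.

In an assay on isolated protein for inhibition of aldehyde dehydrogenase 1A1 (Homo sapiens), read by spectrophotometry, tested at 10 uM (on this read-out lower numbers stand for less inhibition and higher numbers for more inhibition at the one concentration tested (going by the name of the read-out)), compound 1 stands highest of the three numbers. Compound 3 comes nearest, lower by an amount beyond the scatter, and compound 2 lies furthest, also beyond the scatter. Compound 4, `CCCCn1c(CN2CCN(C(=O)C3CC3)CC2)nc2ccccc21`, has not yet been measured. It differs from compound 1 in one place: propyl in place of 2-methylprop-1-en-1-yl on a saturated chain carbon bound to an aromatic nitrogen. Among the measured compounds shown here, no pair of measured compounds isolates this change, so the expectation rests on compound 1 alone. A small downward step is expected, the estimated a number 9.3 percentage points lower from compound 1 to compound 4 (within the scatter) reaching roughly the edge of the scatter. Compound 4 is therefore expected to give about 65%, in a range from 45% to 80%.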

Compound 4, a percentage reported as inhibition, at one concentration (the size of the read-out at that concentration, not a potency): 18.2%
Estimate against measurement, compound 4: 46.8 percentage points above, outside the stated range (below it).
By their numbers in this assay, from the lowest: compound 4; then compound 2; then compound 3; then compound 1.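

In this assay, propyl in place of 2-methylprop-1-en-1-yl on a saturated chain carbon bound to an aromatic nitrogen gives a number 56.1 percentage points lower from compound 1 to compound 4 (beyond the scatter) and so shows that this position is far from indifferent to the chain it carries. With the rest of compound 1 unchanged, removing one carbon and the double bond outside the aromatic rings takes away most of the inhibition. No measurement at hand accounts for this step.

As far as these compounds go, whether the double bond or the carbon count carries the step stays open. So does how a pentyl chain would read at this place on the core of compound 1.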